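The compounds below may be only part of what the source reports. "The series", "measured", "known", "first", "only" and "open" are said of these compounds alone.

Three compounds built on one shared core were measured in an assay on H4 cells for inhibition of Fatty-acid amide hydrolase 1 (Homo sapiens); on this read-out lower numbers stand for stronger inhibition and higher numbers for weaker inhibition. Compound 1 `CCOC(=O)CCCOc1ccc(-n2cnc(-c3ccccc3)c2-c2ccccc2)cc1` gives 64 nM, compound 2 `CCc1nc(-c2ccccc2)c(-c2ccccc2)n1CCCCCCCC(=O)OC` gives 31 nM, and compound 3 `CCOC(=O)CC(C)CCCCCn1c(C)nc(-c2ccccc2)c1-c1ccccc1` gives 130 nM, the highest of the three numbers; its gap to compound 1 and its larger gap to compound 2 both lie beyond the scatter. Compound 4 `Cc1nc(-c2ccccc2)c(-c2ccccc2)n1CCCCCCNC(=O)Oc1ccccc1` differs from compound 3 in a single place: ((phenoxycarbonyl)amino)methyl in place of 1-((ethoxycarbonyl)methyl)ethyl on a saturated chain carbon, five bonds along the chain from an aromatic nitrogen. Among the compounds with values here, no measured pair shows this exact change, so its size can only be an expectation. The step is expected to run downward, toward stronger inhibition, estimated as an 8.7-fold lower number from compound 3 to compound 4 (0.94 log units; beyond the scatter). The estimate for compound 4 is 15 nM in this assay, with a range from 3 nM to 70 nM.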

Compound 4, half-maximal inhibitory concentration: 5.3 nM
Beside the measured number, compound 4's estimate is 2.8-fold (0.45 log units) above it, and the stated range covers the measured number.
By their numbers in this assay, from the lowest: compound 4; then compound 2; then compound 1; then compound 3.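

At this saturated chain carbon, five bonds along the chain from an aromatic nitrogen, ((phenoxycarbonyl)amino)methyl in place of 1-((ethoxycarbonyl)methyl)ethyl gives a 25-fold lower number from compound 3 to compound 4 (1.39 log units; beyond the scatter) in this assay, a large step beyond the scatter. The number at this position therefore depends strongly on the group placed there, and a group with a six-membered aromatic ring and a hydrogen-bond donor is accepted. Nothing available shows which part of the entering group accounts for the step. Still open, from the compounds shown here alone, is whether a urea or an amide in place of the phenoxycarbonylamino part would hold the number this low, and how a longer chain would fare.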